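Methyl on the aromatic ring: one step, repeated

A few compounds are considered here, and "the series" means these few. Any claim that something is new, unique, unknown or untested is made for them only; others in the source may bear on it.

Of the compounds shown here, three have been measured in an assay on CHO cells for displacement of a labelled ligand from histamine receptor H3 (Macaca mulatta); a higher number here means a weaker inhibitor, a lower number a stronger inhibitor. Compound 2 `CC(=O)N1CCCC1C(=O)Nc1ccc(N2CCC(N3CCCC3C)C2)cc1` gives 14.1 nM. Compound 1 `CC(=O)N1CCCC1C(=O)Nc1ccc(N2CCC(N3CCCC3C)C2)c(C)c1` differs from compound 2 by methyl in place of hydrogen on an aromatic carbon. Compound 1 gives 44.9 nM, and the step is a 3.2-fold higher number from compound 2 to compound 1 (0.50 log units; beyond the scatter). Compound 3 `CC1CCCN1C1CCN(c2ccc(NC(=O)C3CCCO3)cc2)C1` differs from compound 2 at the carbonyl carbon, (oxolan-2-yl in place of 1-acetylpyrrolidin-2-yl on a carbonyl carbon). Compound 3 gives 8.7 nM; that step is a 1.6-fold lower number from compound 2 to compound 3 (0.21 log units; within the scatter), so the values of compound 2 and compound 3 are not told apart here.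

Compound 4 `Cc1cc(N2CCC(N3CCCC3C)C2)ccc1NC(=O)C1CCCO1` has not been measured. It differs from compound 3 by methyl in place of hydrogen on an aromatic carbon. Going by the values given here, this is the same kind of change as the one from compound 2 to compound 1, but not the same: around the place, the change into compound 1 sits ortho to a large group, whereas the change into compound 4 sits ortho to a ((oxolan-2-yl)carbonyl)amino group (8 heavy atoms), both being meta to a large group.

Among the compounds with values here, with only one earlier instance of this change, the expectation rests on it alone. The step from compound 3 to compound 4 in this assay is expected to be a 3.1-fold higher number from compound 3 to compound 4 (0.49 log units; beyond the scatter), close to the earlier 3.2-fold higher number from compound 2 to compound 1 (0.50 log units; beyond the scatter), because the earlier step of a 3.2-fold higher number from compound 2 to compound 1 (0.50 log units; beyond the scatter) lay beyond the scatter. Compound 4 is therefore estimated at 27 nM, within a range from 12 nM to 60 nM.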

Compound 4, inhibition constant: 7.34 nM
For compound 4 the middle estimate is 3.7-fold (0.57 log units) above the measured one; measured number outside the range, below it.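

In this assay, methyl in place of hydrogen on an aromatic carbon gives a 1.2-fold lower number from compound 3 to compound 4 (0.07 log units; within the scatter), so the values of these two compounds are not told apart. Set beside the earlier instance, the change does not carry over with the same size from one core to the other in this series: the same change on two cores in this assay, a 3.2-fold higher number (0.50 log units; beyond the scatter) from compound 2 to compound 1 and a 1.2-fold lower number (0.07 log units; within the scatter) from compound 3 to compound 4, 3.8-fold (0.58 log units) apart, beyond the scatter of two such steps. Going by these compounds alone, this shows that the step seen on the core of compound 2 cannot simply be transferred to the core of compound 3, but it does not show what separates the two cases: the group on the carbonyl carbon differs (1-acetylpyrrolidin-2-yl against oxolan-2-yl), the methyl in compound 4 sits ortho to a ((oxolan-2-yl)carbonyl)amino group and meta to a large group, unlike the one in compound 1, and each case is a single pair.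

The compounds shown leave open whether methyl placed ortho to the large group on the core of compound 3 would repeat the step seen for compound 1, which would separate the place of the methyl from the group on the carbonyl carbon. They also leave open whether a chlorine atom or a methoxy group on the same aromatic carbon would behave as methyl does.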